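This account rests on a few compounds, and the source may have more. Where it says the series, first, only, none or still open, it means among the compounds named here.

Series notes. The shared core carries two enone arms on a hydroxylated ring; compound 1 `Cc1cc(O)c(C(=O)/C=C/c2ccc(OCc3ccccc3)cc2)c(-c2ccccc2)c1C(=O)/C=C/c1ccc(OCc2ccccc2)cc1` bears benzyloxy ends and a phenyl group, compound 2 `COc1ccc(/C=C/C(=O)c2c(C)cc(O)c(C(=O)/C=C/c3ccc(OC)cc3)c2-c2ccccc2)cc1` carries methoxy ends on both arms, and compound 3 `COc1ccc(/C=C/C(=O)c2c(C)cc(O)c(C(=O)/C=C/c3ccc(OC)c(OC)c3)c2-c2ccccc2)cc1OC` adds a second methoxy to one arm. In a functional assay on MCF7 cells (Homo sapiens) for cytotoxicity, read by MTT assay, with a stated time of 24 h (a higher number here means a weaker inhibitor, a lower number a stronger inhibitor), compound 1 gives 10000 nM. In this assay compound 2 is recorded as "not active" (no number reported), with no number behind it, and compound 3 likewise stands as "not active" (no number reported). Compound 2 therefore has no single value of its own; the only numeric point in the set is compound 1, and the two methoxy analogues sit without a figure. Compound 4 `COc1ccc(/C=C/C(=O)c2c(C)cc(O)c(C(=O)/C=C/c3ccc(OC)cc3)c2-c2ccc(Br)cc2)cc1` differs from compound 2 by bromo in place of hydrogen on an aromatic carbon. Among the measured compounds shown here, no measured pair shows a step of this kind, so nothing in the data fixes its direction; the nearest anchor is compound 1 at 10000 nM, and compound 2 showed no activity. The expectation for compound 4 in this assay is 15000 nM, with a range from 4000 nM to 60000 nM, and a real chance that only an inactive outcome is reported.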

Compound 4, half-maximal inhibitory concentration: "not active" (no number reported)
The entry for compound 4 holds no number, and the estimate cannot be compared.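

Compound 2 and compound 4 both stand as "not active" without a number in this assay, so no step can be read for phenyl to 4-bromophenyl. Nothing shown bears on the cause of this result. From the compounds shown here alone, what the bromo group does to activity stays open.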